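This account rests on a few compounds, and the source may have more. Where it says the series, first, only, none or still open, it means among the compounds named here.

Series notes on the dichlorophenol-bearing fused compounds measured in a functional assay (aorta) with Oryctolagus cuniculus as the target; a lower number here means tighter binding, a higher number weaker binding. Compound 1 `CCCCc1nc2c(C)cccc2n1Cc1cc(Cl)c(O)c(Cl)c1` gives 20 nM. Compound 3 `CCCc1nc2cccnc2n1Cc1cc(Cl)c(O)c(Cl)c1` gives 31.6 nM. Compound 2 `CCCCc1nc2ncccc2n1Cc1cc(Cl)c(O)c(Cl)c1` gives 398 nM, the highest of the three numbers; its nearest neighbour is compound 3 and its furthest is compound 1, and both gaps lie beyond the scatter, so compound 2 is the weakest of the three measured. Among the measured compounds shown here, compounds 1 and 3 each differ from compound 2 in more than one place, so no single-point step among the measured compounds is available to read the next change against.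

The unmeasured compound 4 `Oc1c(Cl)cc(Cn2c(C3CC3)nc3ncccc32)cc1Cl` differs from compound 2 in one place: cyclopropyl in place of butyl on an aromatic carbon. The butyl chain leaves and the cyclopropyl ring enters on the same aromatic carbon of the core of compound 2. For the measured compounds named here, nothing among the measured compounds varies this group alone; compound 3 carries propyl on a different core and compound 1 carries butyl on a third, and their values do not isolate the effect of the chain.

In this assay the step is expected to be small, most likely toward a lower number but not clearly beyond the scatter: a 1.6-fold lower number from compound 2 to compound 4 (0.20 log units; within the scatter). Compound 4 is therefore estimated at 250 nM, within a range from 80 nM to 800 nM.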

Compound 4, dissociation constant: 631 nM
The estimate for compound 4 lay 2.5-fold (0.40 log units) below the measured number, and the stated range covers the measured number.
By their numbers in this assay, from the lowest: compounds 1 and 3 (each within the scatter of the next); then compounds 2 and 4 (each within the scatter of the next).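

In this assay, among the compounds shown here, the first step at this position that changes one group alone, a 1.6-fold higher number from compound 2 to compound 4 (0.20 log units; within the scatter), shows that cyclopropyl in place of butyl on this aromatic carbon between two ring nitrogen atoms does not move the number beyond the scatter on the core of compound 2. For this pair, then, the read-out does not separate a chain of four carbon atoms with no ring from a three-membered ring of carbon, so the open butyl chain is not needed to hold the number at this level on this core. No measurement shown here bears on why the two groups read alike.

The compounds shown leave open whether the same swap would also stay within the scatter on the core of compound 1 or the core of compound 3, where the step cannot be read from the compounds at hand. They also leave open how this aromatic carbon would respond to a longer chain such as hexyl, to a phenyl ring, or to a group bearing an amine or a carboxylic acid.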